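A few compounds are considered here, and "the series" means these few. Any claim that something is new, unique, unknown or untested is made for them only; others in the source may bear on it.

Compound 3 `Cc1ccc(COc2ccc(C(=O)NC(=S)Nc3ccc(C)c(-c4nc5ccccc5[nH]4)c3)cc2)cc1` gives 4980 nM in a functional assay on MGC-803 cells (Homo sapiens) for inhibition, read by MTT assay, with a stated time of 48 h (on this read-out lower numbers stand for stronger inhibition and higher numbers for weaker inhibition), and stands second highest of the three numbers measured. Compound 1 `Cc1ccc(NC(=S)NC(=O)c2ccc(OCc3cccc(C(F)(F)F)c3)cc2)cc1-c1nc2ccccc2[nH]1` gives 5210 nM in this assay, and the step of a 1.0-fold lower number from compound 1 to compound 3 (0.02 log units; within the scatter) lies within the scatter. Compound 2 `Cc1ccc(NC(=S)NC(=O)c2ccc(OCc3ccccc3F)cc2)cc1-c1nc2ccccc2[nH]1` gives 3070 nM in this assay, and the step of a 1.6-fold higher number from compound 2 to compound 3 (0.21 log units; within the scatter) is also within the scatter, as is a 1.7-fold lower number from compound 1 to compound 2 (0.23 log units; within the scatter). Compound 4 `Cc1ccc(NC(=S)NC(=O)c2ccc(OCc3ccccc3Cl)cc2)cc1-c1nc2ccccc2[nH]1` differs from compound 3 by 2-chlorophenyl in place of 4-methylphenyl on a saturated chain carbon bound to an oxygen on an aromatic ring. All three measured steps change the aryl group at this same place, and none of them moves beyond the scatter, so the step from compound 3 to compound 4 is expected to be small, a 1.3-fold lower number from compound 3 to compound 4 (0.12 log units; within the scatter). Compound 4 is therefore estimated at 3800 nM in this assay, with a range from 2000 nM to 7500 nM.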

Compound 4, half-maximal inhibitory concentration: 45000 nM
The estimate for compound 4 lay 12-fold (1.07 log units) below the measured number; measured number outside the range, above it.
By their numbers in this assay, from the lowest: compounds 2, 3 and 1 (each within the scatter of the next); then compound 4.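

Within the data shown here, at the saturated chain carbon bound to an oxygen on an aromatic ring, the aryl group had so far changed the number only within the scatter, but 2-chlorophenyl breaks that flatness, with a 9.0-fold higher number from compound 3 to compound 4 (0.96 log units; beyond the scatter) and an 8.6-fold higher number from compound 1 to compound 4 (0.94 log units; beyond the scatter) both beyond it. The change can be as small as chloro in place of fluoro on an aromatic carbon, with a 15-fold higher number from compound 2 to compound 4 (1.17 log units; beyond the scatter) as the largest of the three steps. Going by these compounds, whether 4-chlorophenyl or a phenyl group carrying an amine would behave like 2-chlorophenyl remains open. No evidence here bears on the reason for this loss.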